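The source may report more compounds than this note shows. Statements on the series, on what has been measured and on what is new or still open speak of the compounds shown alone.

The measured compounds:

Compound 1, `CCc1ccccc1NC(N)=S`. In a functional assay on B16 cells (Mus musculus) for inhibition, tested at 10 uM (a higher number here means more inhibition at the concentration tested (going by the name of the read-out), a lower number less inhibition), compound 1 gives < 10%, which is a limit of the assay rather than a number.
Compound 2, `CC(C)(C)c1ccccc1NC(N)=S`. Compound 2 gives < 10%, again a limit of the assay.
Compound 3, `CCc1ccc(/C=N/NC(N)=S)cc1`. Compound 3 gives 100%.

Compound 1 and compound 2 share a core and differ in one place: tert-butyl in place of ethyl on an aromatic carbon. For the measured compounds named here, the step that the two limits leave unreadable from compound 1 to compound 2 cannot be sized, since both values sit at the same limit; the only evidence on that pair is the limit of < 10% in this assay, at which 2 of the 3 values shown sit. The core of compound 3 is a different one, and the difference between the two cores is not broken down here.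

Compound 4, `CC(C)(C)c1ccc(/C=N/NC(N)=S)cc1`, has not yet been measured. It is made from compound 3 by the same kind of change: tert-butyl in place of ethyl on an aromatic carbon. The surroundings of the place differ, however: in compound 1 the group sits ortho to a group of 4 heavy atoms, in compound 3 para to a group of 6 heavy atoms.

Since the step from compound 1 to compound 2 is unreadable, the expectation for compound 4 rests on compound 3 alone, whose value of 100% in this assay sits at the top of the range. The step of a number 10 percentage points lower from compound 3 to compound 4 (within the scatter) is expected to be small. Compound 4 is thus estimated to give 90%, with a range from 60% to 100%.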

Compound 4, a percentage reported as inhibition, at one concentration (the size of the read-out at that concentration, not a potency): 100%
Compound 4: the middle estimate sits 10 percentage points below what was measured; the range from low to high includes it.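

In this assay, tert-butyl in place of ethyl on an aromatic carbon, para to a group of 6 heavy atoms, gives no change at the digits printed from compound 3 to compound 4 (within the scatter), so on the core of compound 3 this change leaves the read-out where it stood. This does not show that the change carries over from one core to another, because the matching step on the core of compound 1 cannot be read and gives nothing to set beside the new one: the limit of < 10% in this assay, at which 2 of the 4 values shown sit. Nor does the new step make compound 3 and compound 4 equal in potency: the read-out is a percentage taken at one concentration and is not itself a potency.

The compounds shown leave open whether the read-out on the core of compound 3 would hold with an amine, a carboxylic acid or a longer chain such as hexyl in the same place, and what compound 3 and compound 4 would give at a lower concentration. Also open, as far as these compounds go, is whether any group on the core of compound 1 would bring the read-out clear of the limit of the assay.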